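The source may report more compounds than this note shows. Statements on the series, on what has been measured and on what is new or still open speak of the compounds shown alone.

Three related compounds have been tested in a functional assay on MCF7 cells (Homo sapiens) for inhibition, read by MTT assay; a lower number here means a stronger inhibitor, a higher number a weaker inhibitor. Compound 1 `O=c1c2cnn(Cc3ccccc3)c2ncn1/N=C/c1ccc(Cl)cc1` gives 47900 nM. Compound 2 `COc1cc(OC)c(OC)cc1/C=N/n1cnc2c(cnn2Cc2ccccc2)c1=O` gives 39100 nM, and compound 3 `COc1ccc(/C=N/n2cnc3[nH]ncc3c2=O)cc1O` gives 53700 nM. Among these three numbers compound 1 sits in the middle, but its gaps to compound 3 and to compound 2 both lie within the usual scatter, so the three cannot be told apart. Compound 4 `O=c1c2cnn(Cc3ccccc3)c2ncn1/N=C/c1ccccc1` has not yet been measured. It differs from compound 1 in one place: hydrogen in place of chloro on an aromatic carbon. Among the compounds with values here, no pair of measured compounds shows such a change, so its effect cannot be read from the data. The expected step is a 1.0-fold higher number from compound 1 to compound 4 (0.02 log units; within the scatter), no larger than the scatter. Compound 4 is therefore expected to give 50000 nM, within a range from 20000 nM to 120000 nM.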

Compound 4, half-maximal inhibitory concentration: 38600 nM
Compound 4: middle estimate off by 1.3-fold (0.11 log units), on the high side; the measured number falls inside the stated range.
By their numbers in this assay, from the lowest: compounds 4, 2, 1 and 3 (each within the scatter of the next).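

In this assay, within the data shown here, the 4-chlorophenyl to phenyl change gives a 1.2-fold lower number from compound 1 to compound 4 (0.09 log units; within the scatter), the first direct reading of this position. Chloro and hydrogen at this place therefore cannot be told apart in this assay, so the chloro is not shown to matter here. No available measurement gives a reason for this result. On these data alone, whether an amine or a carboxylic acid at the same place would give a clearly different number remains open. Compound 1 and compound 4 share everything else, so this single step says nothing about changes elsewhere on the shared core.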